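The source may report more compounds than this note shows. Statements on the series, on what has been measured and on what is new or still open speak of the compounds shown alone.

Measured in a functional assay on MDA-MB-231 cells (Homo sapiens) for inhibition, read by sulforhodamine B assay, tested at 10 uM; on this read-out higher numbers stand for more inhibition at the one concentration tested (going by the name of the read-out) and lower numbers for less inhibition:
compound 1 `COC(=O)CC(=O)N1N=C(c2ccc(-n3cncn3)cc2)CC1c1ccc(N(C)C)cc1`: 6.8%
compound 2 `CC(=O)N1N=C(c2ccc(-n3ccnc3)cc2)CC1c1ccc(N(C)C)cc1`: 5%
compound 3 `CN(C)c1ccc(C2CC(c3ccc(-n4ccnc4)cc3)=NN2C(=O)CCCl)cc1`: 2.1%

Compound 3 has the smallest number of the three, but its gap to compound 2 and its gap to compound 1 are both within the scatter, so the three compounds are not separated by this assay.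

Compound 4 `COC(=O)CC(=O)N1N=C(c2ccc(-n3ccnc3)cc2)CC1c1ccc(N(C)C)cc1` differs from compound 3 in one place: methoxycarbonyl in place of chloromethyl on a saturated chain carbon bound to a carbonyl carbon. Among the compounds with values here, the one measured step at this position, a number 2.9 percentage points lower from compound 2 to compound 3 (within the scatter), was within the scatter, so exchanging a group on this chain carbon has not so far moved the read-out. Compound 1 carries the same methoxycarbonyl-bearing chain as compound 4 and differs from it elsewhere; in this assay compound 1 gives 6.8%, again within the scatter of compound 3.

Nothing therefore points to a step beyond the scatter; the expected step is a number 3.9 percentage points higher from compound 3 to compound 4 (within the scatter). Compound 4 is estimated at 6%, in the range 0% to 14%.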

Compound 4, a percentage reported as inhibition, at one concentration (the size of the read-out at that concentration, not a potency): 2.3%
Beside the measured number, compound 4's estimate is 3.7 percentage points above it; the range from low to high includes it.
By their numbers in this assay, from the lowest: compounds 3, 4, 2 and 1 (each within the scatter of the next).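

In this assay, replacing chloromethyl with methoxycarbonyl on a saturated chain carbon bound to a carbonyl carbon gives a number 0.2 percentage points higher from compound 3 to compound 4 (within the scatter) and replacing hydrogen with the same group gives a number 2.7 percentage points lower from compound 2 to compound 4 (within the scatter); hydrogen, chloromethyl and methoxycarbonyl at this position are therefore not separated by this read-out. The series now also has a one-place change on the aromatic carbon, where 1H-imidazol-1-yl in place of 1H-1,2,4-triazol-1-yl gives a number 4.5 percentage points lower from compound 1 to compound 4 (within the scatter), so this exchange is not separated either. No supporting data bear on these results.

Still open, as far as these compounds go, is whether an amine or a carboxylic acid on the same chain carbon, or a longer chain there, would give a step beyond the scatter. Also open, from the compounds shown here alone, is whether a group other than these two azolyl rings on the aromatic carbon, such as a pyridyl ring, would do so.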